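The source may report more compounds than this note shows. Statements on the series, on what has been measured and on what is new or still open speak of the compounds shown alone.

Compound 1 `COc1cc(Oc2cccc(Nc3ccccc3)c2)cc(OC)c1CNCCNC(C)=O` gives 5090 nM in a functional assay on HCT-15 cells (Homo sapiens) for inhibition, read by MTT assay, with a stated time of 72 h; on this read-out lower numbers stand for stronger inhibition and higher numbers for weaker inhibition.
Compound 2 `COc1ccc([C@@H](C)NCc2c(OC)cc(Oc3cccc(Nc4ccccc4)c3)c(OC)c2OC)cc1` gives 4690 nM in this assay.

For the measured compounds named here, of the two compounds measured so far, compound 1 has the higher number, but its gap to compound 2 lies within the usual scatter of this assay, so the two readings cannot be told apart and neither compound can be called the more potent. Compound 3 `CCN1CCN(Cc2c(OC)cc(Oc3cccc(Nc4ccccc4)c3)cc2OC)CC1` has not yet been measured; set against compound 1, it carries 4-ethylpiperazin-1-yl in place of (2-acetamidoethyl)amino on a saturated chain carbon bound to an aromatic carbon. Going by the values given here, no measured pair isolates this change, and compound 2 differs from compound 1 in a different part of the molecule, so it says nothing about the piperazine replacement. With nothing to anchor it, the step of a 1.3-fold lower number from compound 1 to compound 3 (0.10 log units; within the scatter) is expected to be small and not clearly beyond the scatter, in either direction. On that basis compound 3 is expected to give about 4000 nM in this assay, with a range from 1500 nM to 11000 nM.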

Compound 3, half-maximal inhibitory concentration: 5090 nM
Estimate against measurement, compound 3: 1.3-fold (0.10 log units) below; the measured number falls inside the stated range.
By their numbers in this assay, from the lowest: compounds 2, 1 and 3 (each within the scatter of the next).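

On the saturated chain carbon bound to an aromatic carbon, placing 4-ethylpiperazin-1-yl where (2-acetamidoethyl)amino stood gives, in this assay, no change at the digits printed from compound 1 to compound 3 (within the scatter). For the compounds shown here, this is the first measured pair to isolate this position, and it shows that an open chain with 2 hydrogen-bond donors and a double bond outside aromatic rings can give way to a six-membered non-aromatic ring with 0 hydrogen-bond donors without the number leaving the scatter. No measurement offered here explains why these two groups read alike, and the pair alone cannot show whether other groups at this position would do the same.

The compounds shown leave open whether a morpholin-4-yl group, a carboxylic acid or a longer chain on this same carbon would also stay within the scatter of compound 1, or whether any of them would move the number clearly in either direction. They also leave open whether the result holds on the core of compound 1 alone or would recur with other changes elsewhere in the molecule.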